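Amide heteroaryl swap on the pyrrolidine sulfonamide series

A few compounds are considered here, and "the series" means these few. Any claim that something is new, unique, unknown or untested is made for them only; others in the source may bear on it.

Compound 1 `Cc1ccc2[nH]c(C(=O)N[C@H]3CN(S(=O)(=O)c4ccccc4)C[C@@H]3C(=O)N[C@H]3CCCN(C)C3)cc2c1` gives 23 uL/min in an ADME assay on cells (Hepatocyte, Rattus norvegicus) for metabolic stability; on this read-out lower numbers stand for slow clearance and higher numbers for fast clearance. Compound 2 `Cc1ccc2[nH]c(C(=O)N[C@H]3CCN(S(=O)(=O)c4ccccc4Cl)C[C@@H]3C(=O)N[C@H]3CCCN(C)C3)cc2c1` gives 66 uL/min in this assay. Compound 3 `O=C(N[C@H]1CN(S(=O)(=O)c2ccccc2)C[C@@H]1C(=O)N[C@H]1CCCNC1)c1cc(C2CC2)n[nH]1` returns only a limit of this assay, < 1 uL/min, and so stands at the slow end of the values shown, (the limit of < 1 uL/min in this assay, at which 1 of the 3 values shown sits). For the measured compounds named here, no two measured compounds differ in a single place, so no measured step bears directly on the move to compound 4 `O=C(N[C@H]1CN(S(=O)(=O)c2ccccc2)C[C@@H]1C(=O)N[C@H]1CCCNC1)c1cc(-c2ccc(Cl)cc2)on1`. The change is 5-(4-chlorophenyl)-1,2-oxazol-3-yl in place of 3-cyclopropyl-1H-pyrazol-5-yl on a carbonyl carbon. Starting from a limit, the reading for compound 4 can only stay at that limit or move towards faster clearance; a step of moderate size in that direction is expected, an at least 10-fold higher number from compound 3 to compound 4 (1.00 log units; beyond the scatter). Compound 4 is estimated near 10 uL/min, most likely between 2 uL/min and 45 uL/min.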

Compound 4, intrinsic clearance in a liver preparation (reported as CLH), per the amount of preparation that the assay uses in the Hepatocyte assay: 2.22 uL/min
For compound 4 the middle estimate is 4.5-fold (0.65 log units) above the measured one; the measured number falls inside the stated range.
By their numbers in the Hepatocyte assay, from the lowest: compound 4; then compound 1; then compound 2. At a limit, below all of these: compound 3.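

For the compounds shown here, in the Hepatocyte assay, 5-(4-chlorophenyl)-1,2-oxazol-3-yl in place of 3-cyclopropyl-1H-pyrazol-5-yl gives an at least 2.2-fold higher number from compound 3 to compound 4 (0.34 log units; beyond the scatter), the first reading of a change at this place on the carbonyl carbon; the step starts from a limit, so its full size is unknown. In a physicochemical assay for lipophilicity, measured as octanol-water partition, at pH 7.4 (a higher number here means a more lipophilic compound, a lower number a more polar compound), compound 3 gives 0.2 and compound 4 gives 2.1. Both read-outs rise on this single pair, which sets no pattern.

Which part of the entering group carries these steps stays open, since the whole group changes at once. A nitrile in place of the chlorine would test that part of the group.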